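The source may hold more compounds than are shown below. What is called first, only, known or untested is meant among the compounds shown, and "the series" means these compounds.

Measured compounds in a functional assay on KB 3-1 cells (Homo sapiens) for cytotoxicity, read by MTT assay, with a stated time of 68 h; on this read-out lower numbers stand for stronger inhibition and higher numbers for weaker inhibition:

Compound 1, `O=C(Nc1cccc(-c2ccc(-c3ccccc3)cc2)c1)C(Cl)Cl`, gives only a limit of the assay, > 50000 nM.
Compound 2, `O=C(Nc1cccc(-c2cccc(Cl)c2)c1)C(Cl)Cl`, gives only a limit, > 50000 nM.
Compound 3, `COc1ccc(-c2cccc(NC(=O)C(Cl)Cl)c2)cc1`, gives only a limit, > 50000 nM.

Compound 3 therefore stands where the other two stand: every value in this set is the limit of > 50000 nM in this assay, at which 3 of the 3 values shown sit, and no number separates any of the three. Among the compounds with values here, the one step between measured compounds that differ in a single place, a step that the two limits leave unreadable from compound 1 to compound 3, is not readable in size, since both of its ends are limits.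

Compound 4, `O=C(Nc1cccc(-c2ccccc2)c1)C(Cl)Cl`, is not yet measured. It differs from compound 3 as follows: hydrogen in place of methoxy on an aromatic carbon. Within the data shown here, no measured step bears on this change; the only step, from compound 1 to compound 3, gives no readable size, so nothing here points to a step beyond the scatter in either direction.

Compound 4 is thus expected to remain at the limit of this assay, with an estimated value of 70000 nM, the range running from 20000 nM to 250000 nM. The expected step this means is a step that the limit leaves unreadable from compound 3 to compound 4.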

Compound 4, half-maximal inhibitory concentration: 46800 nM
Compound 4: the middle estimate sits 1.5-fold (0.17 log units) above what was measured; low and high end bracket the measured number.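

In this assay, compound 4 gives a number rather than a limit, which sets it apart from the rest of the series: the limit of > 50000 nM in this assay, at which 3 of the 4 values shown sit.

At this position, para to a large group, hydrogen in place of methoxy gives an at least 1.0-fold lower number from compound 3 to compound 4 (0.02 log units; that floor lies within the scatter); hydrogen in place of chloro gives an at least 1.0-fold lower number from compound 2 to compound 4 (0.02 log units; that floor lies within the scatter); hydrogen in place of phenyl gives an at least 1.0-fold lower number from compound 1 to compound 4 (0.02 log units; that floor lies within the scatter). Each of the three is a floor only, and no step beyond the scatter is shown for these changes.

Going by these compounds, the true size of all three steps stays open, with only floors on them. On these data alone, whether an amine or a carboxylic acid at this position would give a number beyond the scatter from compound 4 in this assay also stays open.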